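The compounds below may be only part of what the source reports. "The series", "measured", "known", "first", "only" and "open" are said of these compounds alone.

Measured compounds and their values in this assay:
compound 1 `C=C1C[C@]23C[C@@]1(O)CC[C@H]2c1ccc(OS(=O)(=O)c2ccc(C)cc2)c(C)c1[C@@H]3Cn1cc(-c2ccc(Cl)cc2)nn1` — > 20000 nM
compound 2 `C=C1C[C@]23C[C@@]1(O)CC[C@H]2c1ccc(OS(=O)(=O)c2ccc(C)cc2)c(C)c1[C@@H]3Cn1cc(-c2ccc(Br)cc2)nn1` — > 20000 nM
compound 3 `C=C1C[C@]23C[C@@]1(O)CC[C@H]2c1ccc(OS(=O)(=O)c2ccc(C)cc2)c(C)c1[C@@H]3Cn1cc(-c2ccc(C)cc2)nn1` — > 20000 nM

In a functional assay on SW480 cells (Homo sapiens) for cytotoxicity, read by MTT assay, with a stated time of 4 days (on this read-out higher numbers stand for weaker inhibition and lower numbers for stronger inhibition), compound 3 stands only at a limit, > 20000 nM, not at a number. Compound 1 likewise stands at a limit. Compound 2 also stands at a limit. Because (the limit of > 20000 nM in this assay, at which 3 of the 3 values shown sit), none of the steps among them can be read: a step that the two limits leave unreadable from compound 1 to compound 2, a step that the two limits leave unreadable from compound 1 to compound 3 and a step that the two limits leave unreadable from compound 2 to compound 3 all remain without a readable size. Compound 4 `C=C1C[C@]23C[C@@]1(O)CC[C@H]2c1ccc(OS(=O)(=O)c2ccc(C)cc2)c(C)c1[C@@H]3Cn1cc(-c2ccccn2)nn1` differs from compound 3 in one place: pyridin-2-yl in place of 4-methylphenyl on an aromatic carbon. For the measured compounds named here, no measured step bears on this change, so the expected step that the limit leaves unreadable from compound 3 to compound 4 is taken as none beyond the scatter. Compound 4 is therefore estimated at 30000 nM, within 8000 nM to 100000 nM, most likely reported again as a limit.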

Compound 4, half-maximal inhibitory concentration: > 20000 nM
Compound 4 gave a limit, no number (the forecaster's own chance of this, stated with the estimate: 75%); the middle value lies beyond the limit too.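

No step can be read among compound 1, compound 2, compound 3 and compound 4 in this assay, because each stands only at a limit: the limit of > 20000 nM in this assay, at which 4 of the 4 values shown sit. The compounds shown leave open whether swapping 4-chlorophenyl, 4-bromophenyl, 4-methylphenyl or pyridin-2-yl makes any difference.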